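Methoxy in place of methyl on compound 1

The source may report more compounds than this note shows. Statements on the series, on what has been measured and on what is new or still open speak of the compounds shown alone.

Measured so far:
compound 1 `COc1ccc2cc([C@H](C)c3nnc(SCc4ccc(C)cc4)n3-c3ccc(F)cc3)ccc2c1`: 229000 nM
compound 2 `COc1ccc2cc([C@H](C)c3nnc(SCc4ccc(C)cc4)n3-c3ccc(Cl)cc3)ccc2c1`: 8400 nM

Within the data shown here, in a functional assay on PC-3 cells (Homo sapiens) for cytotoxicity, read by MTT assay (on this read-out lower numbers stand for stronger inhibition and higher numbers for weaker inhibition), compound 1 gives 229000 nM, the higher of the two numbers so far. Compound 3 `COc1ccc(CSc2nnc([C@@H](C)c3ccc4cc(OC)ccc4c3)n2-c2ccc(F)cc2)cc1` differs from it in one place: methoxy in place of methyl on an aromatic carbon. This is methoxy in place of methyl on an aromatic carbon, para to a large group.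

Among the measured compounds shown here, only one measured step bears on this change, and only indirectly: a 27-fold lower number from compound 1 to compound 2 (1.44 log units; beyond the scatter). That step is chloro in place of fluoro on an aromatic carbon. It leaves the methyl group untouched, whereas compound 3 keeps the fluoro, so the data do not show directly what methoxy in place of methyl does here. The step shows only that one substitution moved this number by a large amount in this pair. Compound 1 also sits at the upper end of the two values, so a moderate move towards a lower number is expected, smaller than the measured step and with wide uncertainty.

The expected change is a 3.8-fold lower number from compound 1 to compound 3 (0.58 log units; beyond the scatter). For compound 3 the estimated value is 60000 nM, with an expected range from 10000 nM to 300000 nM.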

Compound 3, half-maximal inhibitory concentration: 400000 nM
Compound 3: middle estimate off by 6.7-fold (0.82 log units), on the low side; measured number outside the range, above it.
By their numbers in this assay, from the lowest: compound 2; then compounds 1 and 3 (each within the scatter of the next).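

In this assay, changing 4-methylbenzyl to 4-methoxybenzyl while keeping the fluoro gives a 1.7-fold higher number from compound 1 to compound 3 (0.24 log units; within the scatter), so this read-out does not separate compound 1 from compound 3. This is the only information shown about this position, since the earlier pair varied only the fluoro and the chloro on a different part of the molecule. Among these compounds, the large step seen there, a 27-fold lower number from compound 1 to compound 2 (1.44 log units; beyond the scatter), has no counterpart in this pair, and methoxy in place of methyl on this aromatic carbon leaves the number within the usual scatter. No measurement available here offers an explanation for this result.

The compounds shown leave open whether this change would also stay within the scatter in the chloro series, with compound 2 as the starting point, since its methoxy counterpart is not among them. They also leave open whether a different group at the same aromatic carbon, such as an amine, a carboxylic acid or a longer alkyl chain in place of methyl, would move the number beyond the scatter in this assay at all.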